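From benzyloxy to 4-bromophenyl on a carbonyl carbon

The source may report more compounds than this note shows. Statements on the series, on what has been measured and on what is new or still open speak of the compounds shown alone.

Among the compounds with values here, in a functional assay on OCI-Ly3 cells (Homo sapiens) for inhibition, read by CellTiter-Glo, with stated times of 48 h and 96 h (on this read-out higher numbers stand for weaker inhibition of growth and lower numbers for stronger inhibition of growth), compound 3 `CC(C)[C@H](NC(=O)OCc1ccccc1)C(=O)N[C@@H](CO)C(=O)N[C@@H](CCCNC(=N)N)C(=O)CF` gives 290 nM, the lowest of three numbers so far. Compound 1 `CC(C)[C@H](NC(=O)c1ccccc1)C(=O)N1CCC[C@H]1C(=O)N[C@@H](CCCNC(=N)N)C(=O)CF` gives 660 nM and compound 2 `CC(C)[C@H](NC(=O)Nc1ccc(Cl)cc1)C(=O)N1CCC[C@H]1C(=O)N[C@@H](CCCNC(=N)N)C(=O)CF` gives 780 nM, and both gaps to compound 3 lie beyond the scatter.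

Compound 4 `CC(C)[C@H](NC(=O)c1ccc(Br)cc1)C(=O)N[C@@H](CO)C(=O)N[C@@H](CCCNC(=N)N)C(=O)CF` has not yet been measured. It carries 4-bromophenyl in place of benzyloxy on a carbonyl carbon.

Within the data shown here, only one measured step involves a swap on such a carbonyl carbon: a 1.2-fold higher number from compound 1 to compound 2 (0.07 log units; within the scatter), with (4-chlorophenyl)amino in place of phenyl. That step stays within the scatter. Among the measured compounds shown here, it is an imperfect guide, since it is a different swap, made on a different remainder of the molecule, and no measured pair tests this exact change.

Going by that single small step, the expected change in this assay is a 1.2-fold higher number from compound 3 to compound 4 (0.08 log units; within the scatter), which is no step beyond the scatter. For compound 4 the estimated value is 350 nM, with an expected range from 130 nM to 900 nM.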

Compound 4, concentration for 50% growth inhibition: 150 nM
Compound 4: the middle estimate sits 2.3-fold (0.37 log units) above what was measured; measured number inside the range.
By their numbers in this assay, from the lowest: compounds 4 and 3 (each within the scatter of the next); then compounds 1 and 2 (each within the scatter of the next).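

Measured in this assay, the swap on this carbonyl carbon stays within the scatter (a 1.9-fold lower number from compound 3 to compound 4 (0.29 log units; within the scatter)). This is the first step shown on the remainder that compound 3 and compound 4 share, and it shows that this position accepts a directly attached 4-bromophenyl in place of benzyloxy without a change beyond the scatter, so the oxygen and the extra carbon of benzyloxy are not needed to keep the number in this range. No measurement shown explains why the two groups give such similar numbers.

The compounds shown leave open whether the bromine itself matters, since no pair separates it from the ring that carries it. They also leave open how this position would respond to a group of another kind, such as an amine, a carboxylic acid or a longer chain ending in a phenyl ring.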